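Benzyl ring substituent series: methyl to nitro at the meta position

The source may hold more compounds than are shown below. What is called first, only, known or untested is meant among the compounds shown, and "the series" means these compounds.

Compound 2 `COc1cccc(OC)c1OCCNCCOc1ccccc1OCc1cccc(C)c1` in a functional assay on thoracic aorta for antagonist activity at Alpha-1D adrenergic receptor (Rattus norvegicus) (a higher number here means a more potent compound, by a factor of ten per unit of this negative logarithm, a lower number a less potent compound), gives 8.85. Compound 1 `COc1cccc(OC)c1OCCNCCOc1ccccc1OCc1ccccc1C` in this assay gives 8.64. For the measured compounds named here, compound 2 has the highest of the two numbers so far, but the step of a number 0.21 log units higher from compound 1 to compound 2 (within the scatter) keeps the two compounds within the scatter, so no order between them can be read from these data.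

Compound 3 `COc1cccc(OC)c1OCCNCCOc1ccccc1OCc1cccc([N+](=O)[O-])c1` is not yet measured. It differs from compound 2 by nitro in place of methyl on an aromatic carbon; the methyl leaves and a nitro group enters on an aromatic carbon of the six-membered carbon-only ring, meta to a large group.

Going by the values given here, no measured step involves a methyl-to-nitro exchange. Among the compounds with values here, the single measured step, from compound 1 to compound 2, moves a methyl between two positions of the same ring and leaves the potency within the scatter. It therefore says nothing about the direction a nitro group would take. The expectation for compound 3 is a step of a number 0.25 log units lower from compound 2 to compound 3 (within the scatter), of uncertain sign, with a wide range. Compound 3 is estimated at 8.6, between 7.9 and 9.3.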

Compound 3, negative logarithm of the antagonist equilibrium constant: 9.28
Compound 3: middle estimate off by 0.68 log units, on the low side, within the range that was stated.
By their numbers in this assay, from the lowest: compounds 1 and 2 (each within the scatter of the next); then compound 3.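

In this assay, for the compounds shown here, nitro in place of methyl on an aromatic carbon, meta to a large group, gives a number 0.43 log units higher from compound 2 to compound 3 (beyond the scatter), the first change in this short series to clear the scatter. The comparison with the 2-methylphenyl compound points the same way, with a number 0.64 log units higher from compound 1 to compound 3 (beyond the scatter), so compound 3 stands apart from both methyl compounds, while those two remain within the scatter of each other and the position of the methyl group alone separates nothing. This position therefore responds to the identity of the group it carries, at least for this one exchange, although nothing at hand bears on why the nitro compound gives the higher number.

One methyl-to-nitro exchange cannot show whether the gain is particular to nitro or would also appear with a nitrile, a carboxylic acid, an amine or a methoxy group on the same aromatic carbon. On these data alone, it also remains open whether nitro at the ring position that carries methyl in compound 1 would match compound 3, so the effect of position on the nitro compounds is still unknown.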